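A Thiophene for a Furan on the Shared Core

The source may report more compounds than this note shows. Statements on the series, on what has been measured and on what is new or still open speak of the compounds shown alone.

Compound 2 `CC1=C(C(=O)OCC2CC2)C(c2ccoc2)NC(=O)N1` stands highest of the two compounds measured in an assay on membranes from CHO cells for displacement of a labelled ligand from adenosine receptor A1 (Homo sapiens), read by scintillation counting, with a stated time of 60 min, tested at 1 uM (a higher number here means more inhibition at the concentration tested (going by the name of the read-out), a lower number less inhibition), where compound 2 gives 29%. Compound 1 `CCCC(=O)C1=C(C)NC(=O)NC1c1cccs1` gives 2% in this assay, a number well below that, beyond the usual scatter; the two differ in more than one place, so their values are simply shown side by side. Compound 3 `CC1=C(C(=O)OCC2CC2)C(c2cccs2)NC(=O)N1` carries a single change from compound 2: thiophen-2-yl in place of furan-3-yl on a saturated ring carbon. Within the data shown here, no directly comparable pair has been measured, so only a modest step is expected, in either direction or none beyond the scatter. Compound 3 is therefore expected to give about 25%, between 5% and 50%. The expected step is a number 4 percentage points lower from compound 2 to compound 3 (within the scatter).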

Compound 3, a percentage reported as inhibition, at one concentration (the size of the read-out at that concentration, not a potency): 23%
The estimate for compound 3 lay 2 percentage points above the measured number, and the stated range covers the measured number.
By their numbers in this assay, from the lowest: compound 1; then compounds 3 and 2 (each within the scatter of the next).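

In this assay, thiophen-2-yl in place of furan-3-yl on the saturated ring carbon gives a number 6 percentage points lower from compound 2 to compound 3 (within the scatter), so this assay does not tell these two rings apart at this position. With thiophen-2-yl held the same, cyclopropylmethoxy in place of propyl on the carbonyl carbon gives a number 21 percentage points higher from compound 1 to compound 3 (beyond the scatter), which shows that the group on the carbonyl carbon matters here. Nothing available explains either step. On these data alone, it remains open how a phenyl ring or a pyridine ring would read on the saturated ring carbon. As far as these compounds go, a longer chain in place of cyclopropylmethoxy is equally open.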